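The source may hold more compounds than are shown below. What is called first, only, known or untested is meant among the compounds shown, and "the series" means these compounds.

Compound 1 `CCOC(=O)CCCOc1cccc(-n2cnc(-c3ccccc3)c2-c2ccccc2)c1`, compound 2 `CCOC(=O)CC(CCCCCn1c(C)nc(-c2ccccc2)c1-c1ccccc1)C(C)C` and compound 3 `CNC(=O)CCCCCCn1c(C)nc(-c2ccccc2)c1-c1ccccc1` share a core carrying two phenyl rings, and differ in what hangs from the chain on the core nitrogen. In an assay on H4 cells for inhibition of Fatty-acid amide hydrolase 1 (Homo sapiens) (a higher number here means a weaker inhibitor, a lower number a stronger inhibitor), compound 1 gives 91 nM. Compound 2 reaches only the limit of this assay, > 100000 nM, and no number is known for it. Compound 3 gives 1700 nM in this assay, the higher of the two numbers that are known, with compound 1 as its nearest neighbour. Going by the values given here, the single step that can be read between neighbours is an at least 58-fold lower number from compound 2 to compound 3 (1.76 log units; beyond the scatter), which shows that the group at the end of the chain can move the number a long way; one of the three values is a limit (the limit of > 100000 nM in this assay, at which 1 of the 3 values shown sits), so the size of that step is itself only a lower bound.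

Compound 4 `Cc1nc(-c2ccccc2)c(-c2ccccc2)n1CCCCCCNC(=O)Oc1ccccc1` is not yet measured. It differs from compound 3 by (phenoxycarbonyl)amino in place of methylcarbamoyl on a saturated chain carbon, six bonds along the chain from an aromatic nitrogen. The measured step bears on it only in that it concerns the same end of the chain, and it gives no direct guide for an entering phenoxycarbonyl amino group. A lower number is expected, an estimated 68-fold lower number from compound 3 to compound 4 (1.83 log units; beyond the scatter), with wide uncertainty. Compound 4 is therefore estimated at 25 nM in this assay, expected to fall between 3 nM and 300 nM.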

Compound 4, half-maximal inhibitory concentration: 5.3 nM
For compound 4 the middle estimate is 4.7-fold (0.67 log units) above the measured one; low and high end bracket the measured number.
By their numbers in this assay, from the lowest: compound 4; then compound 1; then compound 3. At a limit, above all of these: compound 2.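

In this assay, putting (phenoxycarbonyl)amino in place of methylcarbamoyl on a saturated chain carbon, six bonds along the chain from an aromatic nitrogen, gives a 320-fold lower number from compound 3 to compound 4 (2.51 log units; beyond the scatter), and unlike the earlier step at this end of the chain, this one joins two actual numbers and so gives its full size rather than a lower bound. Measured against the branched ester chain end, the same end of the molecule gives an at least 18000-fold lower number from compound 2 to compound 4 (4.27 log units; beyond the scatter), which extends the range the chain end can span. Compound 2 remains only a limit, so that wider step is also only a lower bound: the limit of > 100000 nM in this assay, at which 1 of the 4 values shown sits.

The compounds shown do not separate the contribution of the entering phenyl ring from that of the rest of the (phenoxycarbonyl)amino group, which a (methoxycarbonyl)amino group at the same place would address. They also leave open whether the step would hold with a shorter chain or with a chlorine or methoxy group on the entering phenyl ring.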